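Swapping a Dimethoxyphenyl for Phenyl: What to Expect

The source may report more compounds than this note shows. Statements on the series, on what has been measured and on what is new or still open speak of the compounds shown alone.

Values measured so far in a functional assay on THP-1 cells (Homo sapiens) for inhibition, read by sulforhodamine B assay, with a stated time of 48 h, tested at 50 uM (a higher number here means more inhibition of growth at the concentration tested, a lower number less inhibition of growth), are these
- compound 1 `COc1ccc(/C=C/C(=O)/C=C/c2ccc(OCc3cn(CCCCCOc4cc(=O)oc5ccccc45)nn3)c(OC)c2)cc1OC` gives 47%
- compound 2 `COc1cc(/C=C/C(=O)/C=C/c2cccs2)ccc1OCc1cn(CCOc2cc(=O)oc3ccccc23)nn1` gives 76%
- compound 3 `COc1cc(/C=C/C(=O)/C=C/c2ccccc2)ccc1OCc1cn(CCCCOc2cc(=O)oc3ccccc23)nn1` gives 36%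

Compound 1 stands second highest of these three numbers. Compound 3 lies lower and compound 2 lies higher, and both gaps are beyond the usual scatter of repeated measurements.

The compound still to be tested, compound 4 `COc1cc(/C=C/C(=O)/C=C/c2ccccc2)ccc1OCc1cn(CCCCCOc2cc(=O)oc3ccccc23)nn1`, differs from compound 1 by a single swap: phenyl in place of 3,4-dimethoxyphenyl on a double-bonded chain carbon bound to a double-bonded chain carbon. Put simply, it has phenyl in place of 3,4-dimethoxyphenyl on a double-bonded chain carbon bound to a double-bonded chain carbon.

Among the compounds with values here, no pair of measured compounds differs by this swap alone, so the size of its effect has not been observed directly. The nearest hint is compound 3, which also carries phenyl in that place and gives 36%, though it differs from compound 1 elsewhere too. Compound 2 carries neither group there and gives 76%, so a wide range of values remains possible.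

A small downward move is expected, one that may stay within the scatter. The estimated change is a number 5 percentage points lower from compound 1 to compound 4 (within the scatter). In this assay the estimate for compound 4 is 42%, with an expected range from 25% to 60%.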

Compound 4, percent growth inhibition at one concentration: 26%
Compound 4: middle estimate off by 16 percentage points, on the high side, within the range that was stated.
By their numbers in this assay, from the lowest: compounds 4 and 3 (each within the scatter of the next); then compound 1; then compound 2.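

In this assay, within the data shown here, the swap of 3,4-dimethoxyphenyl for phenyl gives a number 21 percentage points lower from compound 1 to compound 4 (beyond the scatter), and this is the first direct reading of the change, with the rest of the molecule held the same. So the place on a double-bonded chain carbon bound to a double-bonded chain carbon is not a silent one: the group there can shift growth inhibition by more than repeat measurements would, and in this pair the larger 3,4-dimethoxyphenyl, with its 2 hydrogen-bond acceptors, goes with the higher number while phenyl, with 0, goes with the lower. This is a single pair, so it sets no general rule, and no measurement shown here bears on why the number moves with this change.

Among these compounds, the pair cannot separate the two methoxy groups, so what a phenyl carrying only one methoxy group would give in this place stays open, as does the result for a phenyl carrying an amine or a carboxylic acid. Going by these compounds, it is also open whether the swap has a similar effect on a shorter or longer chain joining the triazole-bearing part to the rest of the molecule.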